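From Trifluoromethyl to Methylsulfonyl in a Cytotoxicity Series

The source may report more compounds than this note shows. Statements on the series, on what has been measured and on what is new or still open speak of the compounds shown alone.

In an ADME assay on BJ cells (Homo sapiens) for cytotoxicity, read by CellTiter-Glo and resazurin assay, with a stated time of 72 h (a higher number here means that more compound is needed for the effect, a lower number that less compound is needed), compound 2 (`CCOC(=O)CCCCCOc1cccc(CN(C(=O)c2ccc(-c3cccc(C(F)(F)F)c3)cc2)C(C)C)c1`) gives < 1.3 nM, which is a limit of the assay and not a number. Compound 1 (`CCOC(=O)CCCCCOc1cccc(CN(C(=O)c2ccc(-c3cccc(O)c3)cc2)C(C)C)c1`) gives > 26000 nM, which is also a limit. Compound 2 therefore sits at the low end of the two values shown. Compound 3 (`CCOC(=O)CCCCCOc1cccc(CN(C(=O)c2ccc(-c3cccc(S(C)(=O)=O)c3)cc2)C(C)C)c1`) carries methylsulfonyl in place of trifluoromethyl on an aromatic carbon, meta to a large group: methylsulfonyl in place of trifluoromethyl on an aromatic carbon. For the measured compounds named here, the only measured step at this place is an at least 20000-fold lower number from compound 1 to compound 2 (4.30 log units; beyond the scatter), a large one, with trifluoromethyl in place of hydroxy. Going by that step alone, losing the trifluoromethyl is expected to give a large rise in the number in this assay, though its size is quite uncertain. The expected change is an at least 2300-fold higher number from compound 2 to compound 3 (3.36 log units; beyond the scatter). For compound 3 the estimated value is 3000 nM, within an expected range of 50 nM to 30000 nM.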

Compound 3, half-maximal effective concentration: > 26000 nM
Compound 3 gave a limit, no number (the forecaster's own chance of this, stated with the estimate: 40%); middle value at least 8.6-fold (0.93 log units) away from the limit.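

In this assay, methylsulfonyl in place of trifluoromethyl on the aromatic carbon gives an at least 20000-fold higher number from compound 2 to compound 3 (4.30 log units; beyond the scatter), so the low number of compound 2 is now lost with a second replacement as well as with hydroxy. Compound 3 gives > 26000 nM, a limit of the assay and not a number, so the step between compound 1 and compound 3 cannot be read, and hydroxy and methylsulfonyl cannot be ranked at this place. Of the three groups shown here, only trifluoromethyl goes with the low end of the range: the limit of < 1.3 nM in this assay, at which 1 of the 3 values shown sits.

The compounds shown leave open whether the low number belongs to trifluoromethyl alone or also to a chlorine, a methyl or a nitrile on the same aromatic carbon. They also leave open how the number would respond to a carboxylic acid in place of the ester.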